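The source may hold more compounds than are shown below. What is called first, only, known or untested is meant among the compounds shown, and "the series" means these compounds.

Of the compounds shown here, three have been tested in a functional assay on HepG2 cells (Homo sapiens) for inhibition, read by MTT assay, with a stated time of 48 h (on this read-out higher numbers stand for weaker inhibition and lower numbers for stronger inhibition), and a fourth awaits its number. Compound 1 `Cc1ccc(/C=C2\SC(=O)N(CCNC(=O)Nc3c(C)n(C)n(-c4ccccc4)c3=O)C2=O)cc1` gives 25700 nM in this assay. Compound 2 `COc1ccc(/C=C2\SC(=O)N(CCNC(=O)Nc3c(C)n(C)n(-c4ccccc4)c3=O)C2=O)cc1` differs from it in one place: methoxy in place of methyl on an aromatic carbon. That change produced a 3.1-fold lower number from compound 1 to compound 2 (0.49 log units; beyond the scatter). In this assay compound 2 gives 8370 nM. Compound 3 `Cc1ccc(/C=C2\SC(=O)N(CC(=O)Nc3c(C)n(C)n(-c4ccccc4)c3=O)C2=O)cc1` is built on a different core from compound 1; the difference between the two cores is not broken down here, and in this assay compound 3 gives 57600 nM, the highest of the three numbers. Compound 4 `COc1ccc(/C=C2\SC(=O)N(CC(=O)Nc3c(C)n(C)n(-c4ccccc4)c3=O)C2=O)cc1` stands to compound 3 as compound 2 stands to compound 1: methoxy in place of methyl on an aromatic carbon. The place described around each change is the same, so the two are the same change, made once on each core. Going by the values given here, only one earlier example of it is known, so the expectation rests on a single step. Compound 4 is expected to show a 3.1-fold lower number from compound 3 to compound 4 (0.49 log units; beyond the scatter) in this assay, resting on the step seen from compound 1 to compound 2, a 3.1-fold lower number from compound 1 to compound 2 (0.49 log units; beyond the scatter). On that basis compound 4 is estimated at 18600 nM, with a likely range from 7000 nM to 45000 nM.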

Compound 4, half-maximal inhibitory concentration: 68500 nM
For compound 4 the middle estimate is 3.7-fold (0.57 log units) below the measured one, outside the stated range (above it).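

Replacing methyl with methoxy, which turns 4-methylphenyl into 4-methoxyphenyl, did not carry over from one core to the other in this assay: the same change on two cores in this assay, a 3.1-fold lower number (0.49 log units; beyond the scatter) from compound 1 to compound 2 and a 1.2-fold higher number (0.08 log units; within the scatter) from compound 3 to compound 4, 3.7-fold (0.56 log units) apart, beyond the scatter of two such steps On the core of compound 3, the change gives a 1.2-fold higher number from compound 3 to compound 4 (0.08 log units; within the scatter), so this pair shows no measurable effect, even though the same swap made a clear difference on the core of compound 1. Going by these compounds alone, this shows that, in this small series, a step measured on one core cannot safely be transferred to the other, but with only one pair on each core it does not explain why the two cores respond differently or predict how the change would behave on any further core.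

The compounds shown leave open whether other groups on the same aromatic carbon, such as a chlorine atom, a hydroxyl group or a dimethylamino group, would also give different steps on the two cores. They also leave open how a longer chain, in the part of the structure where the two cores differ, would affect the response to this change.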